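The compounds below may be only part of what the source reports. "The series", "measured", "known", "first", "only" and "open" are said of these compounds alone.

Of the compounds shown here, two have so far been measured in a functional assay on CHO-K1 cells for antagonist activity at cysteinyl leukotriene receptor 1 (Homo sapiens), read by fluorescence and calcium flux, with stated times of 30 min and 1 h; a higher number here means a weaker inhibitor, a lower number a stronger inhibitor. Compound 1 `Cc1c(CCCC(=O)O)c2cccc(/C=C/c3ccc(OCCCCc4c(F)c(F)cc(F)c4F)cc3)c2n1CC(=O)O` gives 2.2 nM in this assay, the lowest of the two numbers. Compound 2 `Cc1c(Cl)cccc1CCCCOc1ccc(C#Cc2cccc3c(CCCC(=O)O)c(C)n(CCC(=O)O)c23)cc1` gives 17 nM in this assay, and the gap between the two numbers lies beyond the usual scatter, so compound 1 is the stronger inhibitor of the pair. Compound 3 `Cc1c(CCCC(=O)O)c2cccc(/C=C/c3ccc(OCCCCc4c(F)ccc(F)c4F)cc3)c2n1CC(=O)O` has not yet been measured. It differs from compound 1 in a single place: hydrogen in place of fluoro on an aromatic carbon. Among the compounds with values here, no pair of measured compounds shows this change on its own, so the data give no direct guide to its size. Removing one fluoro from a tail that keeps three others is expected to leave the number close to where compound 1 stands; the step expected is a 1.6-fold higher number from compound 1 to compound 3 (0.20 log units; within the scatter), a slight weakening that may fall within the scatter. Compound 3 is therefore expected to give 3.5 nM in this assay, within a likely range from 1.3 nM to 9 nM.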

Compound 3, half-maximal inhibitory concentration in the cysteinyl leukotriene receptor 1 assay: 2.4 nM
The estimate for compound 3 lay 1.5-fold (0.16 log units) above the measured number; the range from low to high includes it.
By their numbers in the cysteinyl leukotriene receptor 1 assay, from the lowest: compounds 1 and 3 (each within the scatter of the next); then compound 2.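

In the cysteinyl leukotriene receptor 1 assay, putting hydrogen in place of this fluoro gives a 1.1-fold higher number from compound 1 to compound 3 (0.04 log units; within the scatter), so on inhibition the fluoro at this position makes no visible difference. In a physicochemical assay for permeability, using PAMPA, with a stated time of 4 h, at pH 7.4, tested at 50 uM (on this read-out lower numbers stand for lower permeability and higher numbers for higher permeability), compound 1 gives 0.5 10^-6 cm/s and compound 3 gives 2.6 10^-6 cm/s. The same single change therefore separates the two compounds on permeability while leaving them together on inhibition, and here the tail with one fluoro fewer goes with the higher permeability: the measured apparent permeability of compound 1, 0.5 10^-6 cm/s, and of compound 3, 2.6 10^-6 cm/s, a 5.2-fold higher number (0.72 log units; beyond the scatter)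

On these data alone, whether a methoxy group or a nitrile on this same aromatic carbon would also leave inhibition in place and shift permeability remains open. One pair also cannot show whether taking away a further fluoro from the 2,3,6-trifluorophenyl ring would give a similar result.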